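Swapping the aryl on the shared core for a pyridyl

The source may hold more compounds than are shown below. What is called first, only, known or untested is meant among the compounds shown, and "the series" means these compounds.

Compound 1 `Cn1c(-c2cccc(Cl)c2)nc2c(NC3CCCC3)ncnc21` gives 6.5 nM in an assay on CHO cells for displacement of a labelled ligand from adenosine receptor A1 (Homo sapiens), read by scintillation counting, with a stated time of 3 h; a higher number here means a weaker inhibitor, a lower number a stronger inhibitor.
Compound 2 `Cn1c(-c2ccc(O)cc2)nc2c(NC3CCCC3)ncnc21` gives 17 nM in this assay.
Compound 3 `Cn1c(-c2ccc(C(=O)O)cc2)nc2c(NC3CCCC3)ncnc21` gives 54000 nM in this assay.

Compound 2 stands second highest of the three numbers: compound 1 is nearest, with a 2.6-fold higher number from compound 1 to compound 2 (0.42 log units; beyond the scatter), and compound 3 lies furthest away, with a 3200-fold higher number from compound 2 to compound 3 (3.50 log units; beyond the scatter). Compound 4 `Cn1c(-c2cccnc2)nc2c(NC3CCCC3)ncnc21` is not yet measured; it differs from compound 2 by pyridin-3-yl in place of 4-hydroxyphenyl on an aromatic carbon. For the measured compounds named here, no measured step matches this change. The step from compound 1 to compound 2 shows that exchanging one neutral aryl for another shifts this assay only modestly, whereas the step to compound 3 shows a large loss when a carboxy enters. Pyridin-3-yl carries no carboxy, so a modest step, probably toward a higher number, is expected: a 1.5-fold higher number from compound 2 to compound 4 (0.17 log units; within the scatter). Compound 4 is estimated at 25 nM, within 8 nM to 80 nM.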

Compound 4, inhibition constant: 242 nM
Compound 4: middle estimate off by 9.7-fold (0.99 log units), on the low side; measured number outside the range, above it.
By their numbers in this assay, from the lowest: compound 1; then compound 2; then compound 4; then compound 3.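

In this assay, pyridin-3-yl at this position costs far more than the exchange between the two carbon-only aryl groups did (a 14-fold higher number from compound 2 to compound 4 (1.15 log units; beyond the scatter); a 37-fold higher number from compound 1 to compound 4 (1.57 log units; beyond the scatter)). A large step at this place therefore does not require a carboxy, since the entering group carries no net charge. Nothing available accounts for the size of this step.

As far as these compounds go, what pyridin-4-yl or 4-aminophenyl would give here remains open. From the compounds shown here alone, it is also open whether the step belongs to the ring nitrogen entering or to the hydroxy leaving.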